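A few compounds are considered here, and "the series" means these few. Any claim that something is new, unique, unknown or untested is made for them only; others in the source may bear on it.

Measured so far:
- compound 1 `COc1cc(NC(=O)Nc2cc(Nc3ccc(C(C)(C)C)cc3)ncn2)cc(OC)c1` gives 74.1% in a functional assay on PC-9 cells (Homo sapiens) for inhibition, read by MTT assay, with a stated time of 48 h, tested at 10 uM; a higher number here means more inhibition at the concentration tested (going by the name of the read-out), a lower number less inhibition
- compound 2 `Cc1cc(F)cc(Nc2cc(NC(=O)Nc3c(Cl)cccc3Cl)ncn2)c1` gives 80% in this assay

Among the measured compounds shown here, the two measured compounds share an amide-linked core but differ at both aryl groups, so no single step connects them; their two readings lie within the scatter of each other, and neither is set apart on the numbers seen. Compound 1 therefore stands on a par with compound 2.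

Compound 3 `COc1cc(NC(=O)Nc2cc(Nc3ccc(F)c(Cl)c3)ncn2)cc(OC)c1` is not yet measured. Compared with compound 1 it carries 3-chloro-4-fluorophenyl in place of 4-(tert-butyl)phenyl on a nitrogen on an aromatic ring. For the measured compounds named here, no measured pair isolates this change, so there is no step to lean on; the size of the change in this assay is expected to be none beyond the scatter, with no direction to assign. The step from compound 1 to compound 3 is estimated as a number 2.1 percentage points lower from compound 1 to compound 3 (within the scatter). For compound 3 the estimate is 72%, with a range from 50% to 90%.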

Compound 3, a percentage reported as inhibition, at one concentration (the size of the read-out at that concentration, not a potency): 77.5%
For compound 3 the middle estimate is 5.5 percentage points below the measured one; the measured number falls inside the stated range.
By their numbers in this assay, from the lowest: compounds 1, 3 and 2 (each within the scatter of the next).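

In this assay, among the compounds shown here, the exchange of 4-(tert-butyl)phenyl for 3-chloro-4-fluorophenyl on a nitrogen on an aromatic ring gives the first single-place step, read as a number 3.4 percentage points higher from compound 1 to compound 3 (within the scatter). At this position, an all-carbon group of 10 heavy atoms and a group of 8 heavy atoms bearing fluorine and chlorine are therefore not told apart by this read-out at the one concentration tested. Nothing at hand bears on why the two readings stand so close.

Open, from the compounds shown here alone, is whether a phenyl carrying a basic amine such as morpholine, or a carboxylic acid, would also leave the reading within the scatter at this position. For the compounds shown here, the contribution of the aryl group on the other side of the core also remains open, as no single-place step covers it.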